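Iodo for chloro on the five-membered ring of compound 3

The source may report more compounds than this note shows. Statements on the series, on what has been measured and on what is new or still open speak of the compounds shown alone.

Compound 3 `Fc1ccc(Oc2ncnc3[nH]cc(Cl)c23)c(F)c1` gives 630 nM in an assay on HEK293-TREx cells for antagonist activity at transient receptor potential cation channel subfamily A member 1 (Homo sapiens), read by fluorescence and calcium flux, with a stated time of 72 h (on this read-out higher numbers stand for weaker inhibition and lower numbers for stronger inhibition), and stands at the low end of the three numbers shown, not separable from compound 1 within the scatter but clearly apart from compound 2. Compound 1 `Fc1ccc(Oc2ncnc3[nH]ccc23)c(F)c1` gives 710 nM in this assay, and the step of a 1.1-fold lower number from compound 1 to compound 3 (0.05 log units; within the scatter) lies within the scatter. Compound 2 `CCc1c[nH]c2ncnc(Oc3ccc(F)cc3F)c12` gives 1600 nM in this assay, and the step of a 2.5-fold lower number from compound 2 to compound 3 (0.40 log units; beyond the scatter) is modest but beyond the scatter. Compound 4 `Fc1ccc(Oc2ncnc3[nH]cc(I)c23)c(F)c1` differs from compound 3 by iodo in place of chloro on an aromatic carbon. The measured steps that bear on this change are those at the same aromatic carbon: a 1.1-fold lower number from compound 1 to compound 3 (0.05 log units; within the scatter), within the scatter; a 2.3-fold higher number from compound 1 to compound 2 (0.35 log units; beyond the scatter), modest; and a 2.5-fold lower number from compound 2 to compound 3 (0.40 log units; beyond the scatter), modest. Hydrogen and chloro at this carbon therefore sit within the scatter of each other, while ethyl there gave a modestly higher number. No measured compound carries iodo, so whether iodo follows chloro or ethyl is not shown by these data. Taking the chloro-for-hydrogen step as the closer precedent, the step from compound 3 to compound 4 is expected to be a 1.1-fold lower number from compound 3 to compound 4 (0.02 log units; within the scatter), that is, none beyond the scatter, with a range wide enough to admit a modest rise like the ethyl step. Compound 4 is accordingly expected at 600 nM, between 250 nM and 1500 nM.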

Compound 4, half-maximal inhibitory concentration: 2500 nM
For compound 4 the middle estimate is 4.2-fold (0.62 log units) below the measured one; measured number above the stated range.
By their numbers in this assay, from the lowest: compounds 3 and 1 (each within the scatter of the next); then compounds 2 and 4 (each within the scatter of the next).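

In this assay this aromatic carbon proves less tolerant of change than the hydrogen and chloro pair alone suggested: a 4.0-fold higher number from compound 3 to compound 4 (0.60 log units; beyond the scatter) is modest but beyond the scatter, and a 3.5-fold higher number from compound 1 to compound 4 (0.55 log units; beyond the scatter) is likewise modest, so iodo stands apart from both chloro and hydrogen, even though chloro and iodo each count as a single heavy atom. Iodo does not stand apart from ethyl, as a 1.6-fold higher number from compound 2 to compound 4 (0.19 log units; within the scatter) lies within the scatter, and the four compounds therefore form two sets at this carbon, with hydrogen and chloro in one and ethyl and iodo in the other. Nothing available here accounts for this division between the four groups.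

The compounds shown leave open whether bromo at this carbon would fall with chloro or with iodo, and whether a methyl, a nitrile or an amine there would stay with hydrogen and chloro. They also leave open whether the same division would hold if the rest of the shared core were changed.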